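This account rests on a few compounds, and the source may have more. Where it says the series, first, only, none or still open, it means among the compounds named here.

Measured in a functional assay (blood) for inhibition, with Homo sapiens as the target; on this read-out lower numbers stand for stronger inhibition and higher numbers for weaker inhibition:
- compound 1 `CC(C)(C)Sc1c(CC(C)(C)C(=O)O)n(Cc2ccc(Cl)cc2)c2ccc(OCc3ccc4cc(F)c(F)cc4n3)cc12`: > 3000 nM (a limit)
- compound 2 `COc1ccc2nc(COc3ccc4c(c3)c(SC(C)(C)C)c(CC(C)(C)C(=O)O)n4Cc3ccc(Cl)cc3)sc2c1`: 670 nM
- compound 3 `Cc1nc2ccc(COc3ccc4c(c3)c(SC(C)(C)C)c(CC(C)(C)C(=O)O)n4Cc3ccc(Cl)cc3)cc2s1`: > 3000 nM (a limit)

Compound 3 gives > 3000 nM, which is a limit and not a number. Only compound 2 has a true number, and the other two sit at the limit of > 3000 nM in this assay, at which 2 of the 3 values shown sit.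

Compound 4 `CC(C)(C)Sc1c(CC(C)(C)C(=O)O)n(Cc2ccc(Cl)cc2)c2ccc(OCc3cccc(Cl)n3)cc12` differs from compound 3 in one group: 6-chloropyridin-2-yl in place of 2-methyl-1,3-benzothiazol-6-yl on a saturated chain carbon bound to an oxygen on an aromatic ring. Here 6-chloropyridin-2-yl takes the place of 2-methyl-1,3-benzothiazol-6-yl on a saturated chain carbon bound to an oxygen on an aromatic ring.

Two measured swaps at this same place bear on the change: an at least 4.4-fold lower number from compound 1 to compound 2 (0.65 log units; beyond the scatter), and an at least 4.4-fold higher number from compound 2 to compound 3 (0.65 log units; beyond the scatter). Both lie beyond the scatter, so this group can move the read-out. A third, a step that the two limits leave unreadable from compound 1 to compound 3, cannot be sized. From the compounds shown here alone, none of these swaps brought in 6-chloropyridin-2-yl, so the direction stays open in this assay. Among the compounds with values here, compound 2, at 670 nM, is the only one with a number. A result near the limit is expected, with no clear step.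

The estimated step is an at least 1.2-fold lower number from compound 3 to compound 4 (0.07 log units; that floor lies within the scatter).

Compound 4 is expected at 2500 nM, with an estimated range of 800 nM to 8000 nM.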

Compound 4, half-maximal inhibitory concentration: 410 nM
For compound 4 the middle estimate is 6.1-fold (0.79 log units) above the measured one; the measured number lies below the stated range.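

In this assay a single-ring group is enough at this place: the swap to 6-chloropyridin-2-yl gives an at least 7.3-fold lower number from compound 3 to compound 4 (0.86 log units; beyond the scatter) and also an at least 7.3-fold lower number from compound 1 to compound 4 (0.86 log units; beyond the scatter) when it replaces the larger two-ring groups. Replacing the 6-methoxy-1,3-benzothiazol-2-yl group gives a 1.6-fold lower number from compound 2 to compound 4 (0.21 log units; within the scatter) and so no real change, which means a two-ring group and a single-ring group can sit level here. The first two steps are only floors, because compound 1 and compound 3 stop at a limit and not at a number: the limit of > 3000 nM in this assay, at which 2 of the 4 values shown sit.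

From the compounds shown here alone, whether the chlorine or the ring nitrogen of the new group matters stays open. A plain phenyl, or a pyridin-2-yl with methoxy in place of the chlorine, would help separate the two.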